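A few compounds are considered here, and "the series" means these few. Any claim that something is new, unique, unknown or untested is made for them only; others in the source may bear on it.

Measured so far, in a functional assay on HCT-116 cells (Homo sapiens) for inhibition, read by sulforhodamine B assay, with a stated time of 48 h; on this read-out lower numbers stand for stronger inhibition and higher numbers for weaker inhibition:

compound 1, `COc1ccc(C(c2ccccc2O)c2cccc3ccccc23)c(OC)c1OC`, gives a limit, > 20000 nM

compound 2, `COc1ccc(C(O)(C/C=C\c2ccccc2)c2cccc3ccccc23)c(OC)c1OC`, gives a limit, > 20000 nM

Compound 1 therefore stands at the limit of this assay and not at a number; the limit of > 20000 nM in this assay, at which 2 of the 2 values shown sit, shows that compound 2 stands at the same limit. Among the measured compounds shown here, no step between measured compounds can be drawn, and nothing places compound 1 above or below compound 2.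

Compound 3, `COc1ccc(C(c2ccc(OCC(=O)O)cc2)c2cccc3ccccc23)c(OC)c1OC`, is not yet measured. It differs from compound 1 in one place: 4-(carboxymethoxy)phenyl in place of 2-hydroxyphenyl on a saturated chain carbon bound to two aromatic carbons. For the measured compounds named here, no measured step bears on this change, and the starting point is itself only a limit, so the step from compound 1 to compound 3 cannot be anchored; it is expected to be a number no higher from compound 1 to compound 3 (the limit leaves the size open), that is none beyond the scatter, with a clear chance that the assay again returns only a limit. Compound 3 is accordingly estimated at 20000 nM, within a range of 5000 nM to 60000 nM.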

Compound 3, half-maximal inhibitory concentration: 5020 nM
Compound 3: the middle estimate sits 4.0-fold (0.60 log units) above what was measured; measured number inside the range.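

Replacing 2-hydroxyphenyl with 4-(carboxymethoxy)phenyl on a saturated chain carbon bound to two aromatic carbons gives an at least 3.9-fold lower number from compound 1 to compound 3 (0.60 log units; beyond the scatter) in this assay. Compound 3, at 5020 nM, is the only compound shown with a number, so this position can bring the read-out to a number, which the earlier compounds did not show. Compound 1 gives only a limit, > 20000 nM, so the step has a lower bound but no full size: the limit of > 20000 nM in this assay, at which 2 of the 3 values shown sit.

The compounds shown do not separate the contribution of the carboxylic acid from that of the ether link or of the change in where the ring is substituted, and a 4-hydroxyphenyl or 4-methoxyphenyl group would bear on that. From the compounds shown here alone, how a methyl ester, an amine or a longer chain in place of the carboxymethoxy group would read also stays open.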